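The source may hold more compounds than are shown below. What is called first, only, known or untested is meant among the compounds shown, and "the series" means these compounds.

Series so far, read in a functional assay on HEp-2 cells (Homo sapiens) for inhibition; a lower number here means that less compound is needed, a higher number that more compound is needed for the effect:

- compound 1 `CSc1ncnc2[nH]nnc12`: > 300 uM
- compound 2 `COc1ncnc2c1nnn2[C@@H]1O[C@H](CO)[C@@H](O)[C@H]1O`: 0.3 uM

Compound 1 gives the result > 300 uM, which is a limit of the assay and not a number.

Within the data shown here, compound 2 gives 0.3 uM, the only true number available in this assay. The one other result sits at a limit, as noted in the limit of > 300 uM in this assay, at which 1 of the 2 values shown sits, so the two compounds show a wide gap, but its size cannot be read exactly.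

The next compound is compound 3 `OC[C@H]1O[C@@H](n2nnc3c(S)ncnc32)[C@H](O)[C@@H]1O`. It keeps the structure of compound 2 except for sulfanyl in place of methoxy on an aromatic carbon.

Among the measured compounds shown here, no step between measured compounds is available to scale this exchange, so the expectation is a judgement with a wide margin. For the measured compounds named here, the only anchor is compound 2 at 0.3 uM. A moderate loss in this assay is expected, meaning a higher number, probably beyond the usual scatter. The estimated change is a 6.7-fold higher number from compound 2 to compound 3 (0.82 log units; beyond the scatter). For compound 3 the expected value is 2 uM, within an estimated range of 0.2 uM to 30 uM.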

Compound 3, concentration for half-maximal effect: 1 uM
For compound 3 the middle estimate is 2.0-fold (0.30 log units) above the measured one; low and high end bracket the measured number.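

In this assay, sulfanyl in place of methoxy on the aromatic carbon next to the ring nitrogen gives a 3.3-fold higher number from compound 2 to compound 3 (0.52 log units; beyond the scatter), a modest step that lies beyond the scatter, so the exchange at this position is not neutral. Compound 3 still gives a true number, 1 uM, and not a limit, which shows that methoxy at this position is not required for a measurable effect in this assay. No measured property shown here bears on this step, and nothing shown accounts for its size.

The exchange replaces two heavy atoms with one and brings in a hydrogen-bond donor, and a single step cannot show which of these differences, if either, goes with the higher number. On these data alone, how an amine or a chlorine atom on the same aromatic carbon would read against methoxy and sulfanyl remains open, as does whether the size of this step would hold for other groups at this position.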